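The compounds below may be only part of what the source reports. "The series", "measured", "known", "first", "only" and "open" are said of these compounds alone.

Measured compounds in this series:
compound 1 `O=C(Nc1ccc(Br)cc1)N[C@H]1CC[C@H](Oc2ccc(F)cc2)CC1` — > 20000 nM
compound 2 `O=C(Nc1cccc([N+](=O)[O-])c1)N[C@H]1CC[C@H](Oc2ccc(F)cc2)CC1` — 6700 nM
compound 3 `Cc1ccccc1NC(=O)N[C@H]1CC[C@H](Oc2ccc(F)cc2)CC1` — > 20000 nM

In a functional assay on CRL2813 cells (Homo sapiens) for cytotoxicity, read by sulforhodamine B assay, with a stated time of 5 days (a lower number here means a stronger inhibitor, a higher number a weaker inhibitor), compound 1 sits at > 20000 nM, which is a limit of the assay and not a number. Compound 3 likewise sits at a limit, > 20000 nM. Among the measured compounds shown here, compound 2 gives 6700 nM, the only number in the set. The steps read: an at least 2.9-fold lower number from compound 1 to compound 2 (0.47 log units; beyond the scatter); an at least 2.9-fold higher number from compound 2 to compound 3 (0.47 log units; beyond the scatter); and a step that the two limits leave unreadable from compound 1 to compound 3, since both ends are limits. Two of three values share (the limit of > 20000 nM in this assay, at which 2 of the 3 values shown sit), so compound 1 stands at the weak end of what this assay can report.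

Compound 4 `O=C(Nc1ccccc1Cl)N[C@H]1CC[C@H](Oc2ccc(F)cc2)CC1` is the next compound, differing from compound 1 in one place: 2-chlorophenyl in place of 4-bromophenyl on an amide-type nitrogen. Of the measured steps, the move to compound 3, a 2-methylphenyl on the same nitrogen, is the closest in kind, and it left the value at a limit. For the measured compounds named here, the only step that lowered the number, from compound 1 to compound 2, brought in a 3-nitrophenyl, which compound 4 lacks. Compound 4 is therefore expected to stay near the limit, with no step beyond the scatter foreseen in this assay, so a number no higher from compound 1 to compound 4 (the limit leaves the size open) is the expected step. The estimate for compound 4 is 20000 nM, with a range from 7000 nM to 50000 nM.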

Compound 4, half-maximal inhibitory concentration: 9100 nM
Estimate against measurement, compound 4: 2.2-fold (0.34 log units) above, and the stated range covers the measured number.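

In this assay, 2-chlorophenyl in place of 4-bromophenyl on the amide-type nitrogen gives an at least 2.1-fold lower number from compound 1 to compound 4 (0.34 log units; beyond the scatter), so a readable cytotoxic value in this small set no longer belongs to the 3-nitrophenyl of compound 2 alone. Chloro in place of methyl on an aromatic carbon gives an at least 2.1-fold lower number from compound 3 to compound 4 (0.34 log units; beyond the scatter), so 2-chlorophenyl and 2-methylphenyl do not read alike in this assay, and this is the cleanest single change in the set. The 2-chlorophenyl and 3-nitrophenyl groups cannot be ordered, with a 1.4-fold higher number from compound 2 to compound 4 (0.13 log units; within the scatter).

The true size of the steps starting from compound 1 and compound 3 stays open, since each of these compounds sits at a limit of the assay and not at a number: the limit of > 20000 nM in this assay, at which 2 of the 4 values shown sit.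

Also open, from the compounds shown here alone, is how an aminophenyl, a methoxyphenyl or a longer chain in place of the phenyl would read in this assay, and whether bromo and chloro differ on their own, as compound 1 and compound 4 differ in both the halogen and its place on the phenyl.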